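Compound 4: a thiophene swap at the assay limit

The source may report more compounds than this note shows. Statements on the series, on what has been measured and on what is new or still open speak of the compounds shown alone.

Compound 1 (`O=C(Nc1cccc(-c2ccsc2)c1)C(Cl)Cl`) gives > 50000 nM as a limit
Compound 2 (`O=C(Nc1cccc(-c2ccccn2)c1)C(Cl)Cl`) gives > 50000 nM as a limit
Compound 3 (`COc1cccc(-c2cccc(NC(=O)C(Cl)Cl)c2)c1`) gives 43300 nM as a number

All three were tested in a functional assay on KB 3-1 cells (Homo sapiens) for cytotoxicity, read by MTT assay, with a stated time of 68 h (on this read-out lower numbers stand for stronger inhibition and higher numbers for weaker inhibition), and the account follows one step from there. Compound 2 has no number of its own, only the limit > 50000 nM in this assay and nothing more. The same holds for one other compound, so the series sits largely at the limit of > 50000 nM in this assay, at which 2 of the 3 values shown sit, with a single number beside it.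

The step leads to compound 4 (`O=C(Nc1cccc(-c2cccs2)c1)C(Cl)Cl`), where thiophen-2-yl stands in place of pyridin-2-yl on an aromatic carbon (thiophen-2-yl in place of pyridin-2-yl on an aromatic carbon). For the measured compounds named here, the only measured step that bears on this one is a step that the two limits leave unreadable from compound 1 to compound 2 and it gives no size to carry over. Compound 1, which carries thiophen-3-yl on the shared core, also stops at a limit (> 50000 nM) in this assay as reported. Going by the values given here, compound 3 gives the only number (43300 nM).

No step beyond the usual scatter is therefore expected, in either direction. The estimated step is an at least 1.1-fold lower number from compound 2 to compound 4 (0.04 log units; that floor lies within the scatter) and it is expected to be small. Compound 4 is estimated at 45000 nM with an expected range from 22000 nM to 90000 nM in this assay and a report of only a limit is quite likely.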

Compound 4, half-maximal inhibitory concentration: > 50000 nM
Compound 4 gave a limit, no number; the forecaster's own chance of this, stated with the estimate: 60%; middle value at least 1.1-fold (0.04 log units) away from the limit.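

In this assay compound 4 gives > 50000 nM, a limit and not a number, so its steps from compound 1 and from compound 2 cannot be read. The compounds shown leave open how thiophen-2-yl, thiophen-3-yl and pyridin-2-yl compare on the shared core, with the series resting largely at one value: the limit of > 50000 nM in this assay, at which 3 of the 4 values shown sit.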